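Swapping the benzyl halide in a triazole-linked chalcone series

The compounds below may be only part of what the source reports. "The series", "measured", "known", "first", "only" and "open" are said of these compounds alone.

In a functional assay on MIA PaCa-2 cells (Homo sapiens) for inhibition, read by MTT assay, with a stated time of 48 h, tested at 10 uM (a higher number here means more inhibition of growth at the concentration tested, a lower number less inhibition of growth), three compounds have numbers: compound 1 `C#CCOc1ccc(/C=C/C(=O)c2ccc([N+](=O)[O-])cc2)cc1` gives 42%; compound 2 `O=C(/C=C/c1ccc(OCc2cn(Cc3ccccc3Br)nn2)cc1)c1ccc(Br)cc1` gives 43%; compound 3 `O=C(/C=C/c1ccc(OCc2cn(Cc3ccc(Br)cc3)nn2)cc1)c1ccc(Br)cc1` gives 29%.

Compound 2 holds the highest of the three numbers, but compound 1 sits within the scatter of it, so no order between those two can be claimed; only compound 3 lies clearly lower. Compound 4 `O=C(/C=C/c1ccc(OCc2cn(Cc3ccc(F)cc3)nn2)cc1)c1ccc(Br)cc1` differs from compound 2 by 4-fluorophenyl in place of 2-bromophenyl on a saturated chain carbon bound to an aromatic nitrogen. For the measured compounds named here, the one measured step that bears on this is a number 14 percentage points lower from compound 2 to compound 3 (beyond the scatter), where the bromine moved to the same position that the fluorine takes in compound 4. Going by the values given here, no measured pair shows fluorine against bromine. A modest drop is therefore expected, a number 11 percentage points lower from compound 2 to compound 4 (beyond the scatter). Compound 4 is estimated at 32%, within 18% to 46%.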

Compound 4, percent growth inhibition at one concentration: 32%
Compound 4: middle estimate and measured number agree at the digits printed, within the range that was stated.
By their numbers in this assay, from the lowest: compounds 3, 4, 1 and 2 (each within the scatter of the next, the first and the last beyond it).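

In this assay the 4-fluorophenyl group also gives a number 11 percentage points lower from compound 2 to compound 4 (beyond the scatter), so the fall seen with compound 3 does not depend on bromine alone. Fluoro in place of bromo on an aromatic carbon gives a number 3 percentage points higher from compound 3 to compound 4 (within the scatter), so compounds 3 and 4 cannot be told apart here. No measured property is available to explain these numbers.

On these data alone, whether fluorine would keep the number of compound 2 if it replaced the bromine of the 2-bromophenyl group stays open. So does the effect of an amine or a carboxylic acid in place of the halogen.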